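Swapping Morpholine for Methylpiperazine in a Fused Amidine

This account rests on a few compounds, and the source may have more. Where it says the series, first, only, none or still open, it means among the compounds named here.

The shared core carries a phenyl group and a carboxymethyl group, and differs across the three compounds in the ring attached to the carbon with a double bond to nitrogen. Compound 1 `COC(=O)CC1c2ccccc2N=C(N2CCN(C)CC2)N1c1ccccc1` bears a methyl ester and a 4-methylpiperazin-1-yl group, and in a functional assay on cells (Oocyte) for inhibition of Voltage-dependent T-type calcium channel subunit alpha-1H (Homo sapiens), tested at 100 uM (a higher number here means more inhibition at the concentration tested (going by the name of the read-out), a lower number less inhibition), compound 1 gives 15%. Compound 2 `O=C(O)CC1c2ccccc2N=C(N2CCOCC2)N1c1ccccc1` bears the free acid and a morpholin-4-yl group, and in this assay compound 2 gives 9%; the gap to compound 1 lies within the usual scatter, so the two cannot be told apart. Compound 3 `CN1CCN(C2=Nc3ccccc3C(CC(=O)O)N2c2ccccc2)CC1` combines the free acid of compound 2 with the ring of compound 1. Compared with compound 2, the change is 4-methylpiperazin-1-yl in place of morpholin-4-yl on a carbon with a double bond to nitrogen. Among the measured compounds shown here, no measured pair isolates this change, so the expected step from compound 2 to compound 3 is a number 3 percentage points higher from compound 2 to compound 3 (within the scatter), which is none beyond the scatter. Compound 3 is expected to give about 12%, somewhere between 0% and 28%.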

Compound 3, a percentage reported as inhibition, at one concentration (the size of the read-out at that concentration, not a potency): 15%
The estimate for compound 3 lay 3 percentage points below the measured number; low and high end bracket the measured number.
By their numbers in this assay, from the lowest: compounds 2, 1 and 3 (each within the scatter of the next).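

In this assay, the direct swap of morpholin-4-yl for 4-methylpiperazin-1-yl on the free acid gives a number 6 percentage points higher from compound 2 to compound 3 (within the scatter) and therefore shows no effect that can be told apart from the scatter. With 4-methylpiperazin-1-yl in place, the exchange of the methyl ester for the free acid gives no change at the digits printed from compound 1 to compound 3 (within the scatter) and so leaves the two forms indistinguishable as well. No available evidence explains either result.

As far as these compounds go, whether a different group on this carbon, such as piperidin-1-yl or an open-chain dimethylamino group, would produce a step beyond the scatter remains open. The compounds also leave open whether an amide or a longer chain ending in a carboxylic acid, in place of the carboxymethyl group, would change the inhibition.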